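Ester chain length and cytotoxic read-out: compound 4

A few compounds are considered here, and "the series" means these few. Any claim that something is new, unique, unknown or untested is made for them only; others in the source may bear on it.

The series shares one core and varies only the ester chain. Compound 1 `CCCCCCOC(=O)CCC(=O)N1CCN(CCCOc2cc3c(Nc4ccc(F)c(Cl)c4)ncnc3cc2OC)CC1` gives 42.9% in a functional assay on A549 cells (Homo sapiens) for cytotoxicity, read by MTT assay, with a stated time of 24 h, tested at 80 uM; a higher number here means a weaker effect of the compound at the concentration tested, a lower number a stronger effect. Compound 2 `CCCCCCCCCCCOC(=O)CCC(=O)N1CCN(CCCOc2cc3c(Nc4ccc(F)c(Cl)c4)ncnc3cc2OC)CC1` gives 2.8%, and compound 3 `CCCCCCCCCCCCCCOC(=O)CCC(=O)N1CCN(CCCOc2cc3c(Nc4ccc(F)c(Cl)c4)ncnc3cc2OC)CC1` gives 77.2%, the highest of the three numbers. The steps are not in one direction: a number 40.1 percentage points lower from compound 1 to compound 2 (beyond the scatter), whereas a number 34.3 percentage points higher from compound 1 to compound 3 (beyond the scatter) and a number 74.4 percentage points higher from compound 2 to compound 3 (beyond the scatter).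

Compound 4 `CCCCCCCCCCCCCCCCCOC(=O)CCC(=O)N1CCN(CCCOc2cc3c(Nc4ccc(F)c(Cl)c4)ncnc3cc2OC)CC1` is the next chain extension and differs from compound 3 by propyl in place of hydrogen on a saturated chain carbon, ten or more bonds along the chain from an oxygen next to a carbonyl group. Going by the values given here, the only step of the same kind is a number 74.4 percentage points higher from compound 2 to compound 3 (beyond the scatter), which points upward, but compound 3 already sits near the upper end of the scale, and the reversal between compound 1 and compound 2 shows that chain length alone does not give a steady trend. The expectation is therefore a small step or none beyond the scatter, a number 2.8 percentage points higher from compound 3 to compound 4 (within the scatter). Compound 4 is estimated at 80%, between 50% and 100%.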

Compound 4, a percentage reported as activity, at one concentration (the size of the read-out at that concentration, not a potency): 83.2%
Beside the measured number, compound 4's estimate is 3.2 percentage points below it; the measured number falls inside the stated range.
By their numbers in this assay, from the lowest: compound 2; then compound 1; then compounds 3 and 4 (each within the scatter of the next).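

Propyl in place of hydrogen on a saturated chain carbon does not repeat the earlier large rise in this assay (compound 2 to compound 3: a number 74.4 percentage points higher from compound 2 to compound 3 (beyond the scatter); compound 3 to compound 4: a number 6 percentage points higher from compound 3 to compound 4 (within the scatter)). Compounds 3 and 4 therefore form a pair at the high end of the scale, and both compound 1 and compound 2 stay clearly apart from compound 4 (a number 40.3 percentage points higher from compound 1 to compound 4 (beyond the scatter); a number 80.4 percentage points higher from compound 2 to compound 4 (beyond the scatter)), with the largest gap at compound 2. No measurement shown accounts for this levelling or for the low number of compound 2.

Open, as far as these compounds go, is how sharply the read-out changes with chain length on either side of compound 2, and whether a longer chain than that of compound 4 stays at this level. Also open, from the compounds shown here alone, is whether an amine or a carboxylic acid carried on the ester chain would alter the read-out.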